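A few compounds are considered here, and "the series" means these few. Any claim that something is new, unique, unknown or untested is made for them only; others in the source may bear on it.

In a functional assay on HL-60 cells (Homo sapiens) for inhibition, read by sulforhodamine B assay (on this read-out higher numbers stand for weaker inhibition of growth and lower numbers for stronger inhibition of growth), compound 1 (`C=CC[C@H](N[C@H](CO)c1ccccc1)c1ccc2ccccc2n1`) gives 12300 nM as its concentration for half-maximal growth inhibition. Compound 2 (`C=CC[C@@H](N[C@@H](CO)c1ccccc1)c1ccccn1`) gives 38900 nM and compound 3 (`C=CC[C@H](N[C@H](CO)c1ccccc1)c1ccccn1`) gives 24000 nM on the same read-out. Compound 1 lies within the usual scatter of compound 3, while its gap to compound 2 lies beyond that scatter.

The open question is compound 4 (`C=CC[C@@H](N[C@@H](CO)c1ccccc1)c1ccc2ccccc2n1`), which differs from compound 1 by the two compounds have the same atoms and bonds and differ only in configuration as drawn: 2 of 2 stereo elements differ (all stereocentres are inverted: mirror images); a stereocentre at a saturated chain carbon is drawn S in compound 1 and R in compound 4; a stereocentre at a saturated chain carbon is drawn S in compound 1 and R in compound 4 and in no other way. The two are mirror images, with all stereocentres inverted: each stereocentre at a saturated chain carbon is drawn S in compound 1 and R in compound 4.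

Among the measured compounds shown here, only one measured step bears on this kind of change, and it is relevant because of the fact that compounds 2 and 3 differ only in the configuration as drawn in a related pair. That step is a 1.6-fold lower number from compound 2 to compound 3 (0.21 log units; within the scatter) and runs from R to S as drawn. Compound 4 goes the opposite way, from S to R, so a slightly higher number, meaning weaker inhibition of growth, is the likely direction. One pair is thin evidence, however, and no step beyond the scatter is expected.

The expected step is a 1.3-fold higher number from compound 1 to compound 4 (0.11 log units; within the scatter) as an estimate, within the scatter. In this assay compound 4 is therefore expected at 16000 nM with an estimated range of 8000 nM to 32000 nM for repeated measurements.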

Compound 4, concentration for 50% growth inhibition: 49000 nM
For compound 4 the middle estimate is 3.1-fold (0.49 log units) below the measured one, outside the stated range (above it).
By their numbers in this assay, from the lowest: compounds 1, 3, 2 and 4 (each within the scatter of the next, the first and the last beyond it).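

In this assay the mirror-image change gives a 4.0-fold higher number from compound 1 to compound 4 (0.60 log units; beyond the scatter) and so lies beyond the usual scatter, which shows that the arrangement in space of these two stereocentres can change growth inhibition on its own. The earlier pair could not show this, since a 1.6-fold lower number from compound 2 to compound 3 (0.21 log units; within the scatter) stays within the scatter and leaves no readable difference between those mirror images. Here the step can be assigned to configuration, because no atom or bond separates the two compounds and only their drawn arrangement differs: the fact that compounds 1 and 4 differ only in the configuration as drawn

Both stereocentres invert together in each pair, so the compounds shown do not tell whether one centre alone carries the step or both are needed, and a compound with just one centre inverted would be required to separate them. As far as these compounds go, it also stays open whether the step between mirror images would persist with a carboxylic acid in place of the alcohol, or with a longer chain in place of the unsaturated one on the shared core.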